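The source may report more compounds than this note shows. Statements on the series, on what has been measured and on what is new or still open speak of the compounds shown alone.

Working notes on the series.

Compound 1, `Cc1ccc(Cn2cc(COc3ccc4c(=O)ccoc4c3)nn2)cc1`, gives 10400 nM in a functional assay on SW480 cells (Homo sapiens) for cytotoxicity, read by MTT assay, with a stated time of 48 h; a lower number here means a stronger inhibitor, a higher number a weaker inhibitor. Compound 2, `O=c1ccoc2cc(OCc3cn(Cc4ccc(F)cc4)nn3)ccc12`, gives 11200 nM in this assay. Among the compounds with values here, the only single-point step so far is a 1.1-fold higher number from compound 1 to compound 2 (0.03 log units; within the scatter), so compound 2 stands as the higher of the two numbers, with compound 1 the nearest neighbour and the gap between them inside the scatter; no order between the two can be claimed.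

Compound 3, `CC(C)(C)c1ccc(Cn2cc(COc3ccc4c(=O)ccoc4c3)nn2)cc1`, has not yet been measured in this assay. It differs from compound 2 by tert-butyl in place of fluoro on an aromatic carbon. Within the data shown here, the one step that bears on this position is a 1.1-fold higher number from compound 1 to compound 2 (0.03 log units; within the scatter), which exchanged two small groups at the same place without moving the number beyond the scatter. Among the measured compounds shown here, no measured step covers a tert-butyl group anywhere, so the data give no direction for a change of this size, only the observation that the two substituents tried so far at this place read alike. The step of a 1.0-fold lower number from compound 2 to compound 3 (0.01 log units; within the scatter) is therefore expected to stay within the scatter, with a wide allowance for the untested group. Compound 3 is estimated at 11000 nM, with a range from 4000 nM to 32000 nM.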

Compound 3, half-maximal inhibitory concentration: 28800 nM
Compound 3: the middle estimate sits 2.6-fold (0.42 log units) below what was measured, and the stated range covers the measured number.
By their numbers in this assay, from the lowest: compounds 1 and 2 (each within the scatter of the next); then compound 3.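

At this place, on an aromatic carbon para to a large group, the substituent can move the number in this assay: tert-butyl in place of fluoro gives a 2.6-fold higher number from compound 2 to compound 3 (0.41 log units; beyond the scatter) and tert-butyl in place of methyl gives a 2.8-fold higher number from compound 1 to compound 3 (0.44 log units; beyond the scatter). Both steps are modest, but they lie beyond the scatter and point the same way, toward a weaker inhibitor, so this place is not indifferent to every group, as the methyl and fluoro pair alone might have suggested; among the three compounds, compound 3 is the weakest. The change counted here is fluoro, with 1 heavy atom, leaving and tert-butyl, with 4 heavy atoms, entering, with no ring, hydrogen-bond donor, acceptor or net charge on either side, and no measurement in hand bears on why the number rises.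

Three hydrocarbon or halogen substituents cannot show whether the number climbs steadily with the count of heavy atoms, and an isopropyl or a phenyl group at this place would test that. Going by these compounds, how an amine, a carboxylic acid or a methoxy group would read here remains open, as does whether the same change at another place on this ring would give a similar step.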